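The source may report more compounds than this note shows. Statements on the series, on what has been measured and on what is new or still open speak of the compounds shown alone.

Compounds measured so far:
compound 1 `Nc1ccccc1/C=C/c1ccc(O)cc1`, > 100 ug/mL in a functional assay on HT-29 cells (Homo sapiens) for inhibition, read by MTT assay, with a stated time of 2 days (a higher number here means a weaker inhibitor, a lower number a stronger inhibitor), a limit of the assay;
compound 2 `Nc1ccc(/C=C/c2ccccc2O)cc1`, 37 ug/mL;
compound 3 `COc1ccccc1/C=C/c1ccc(O)cc1`, 24 ug/mL.

Compound 3 carries the lowest number among the measured compounds. Its nearest neighbour is compound 2, which sits within the scatter of it, so no order between the two can be read. Compound 1 gives only a limit in this assay, and the step of an at least 4.1-fold lower number from compound 1 to compound 3 (0.61 log units; beyond the scatter) is therefore itself a lower bound; this limit is the one thing that bears on the measured step (the limit of > 100 ug/mL in this assay, at which 1 of the 3 values shown sits).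

Compound 4 `COc1ccccc1/C=C/c1ccc(N)cc1` differs from compound 3 in one place: amino in place of hydroxy on an aromatic carbon. Going by the values given here, no measured step covers this exchange. Among the compounds with values here, the only measured step, from compound 1 to compound 3, swaps methoxy for amino at a different place and bears on it only indirectly. Compounds 1 and 2 differ in two places and their values show that an amino-bearing stilbene core can reach a number near that of compound 3. The expected step of a 1.5-fold higher number from compound 3 to compound 4 (0.16 log units; within the scatter) is therefore small, within the scatter, with a slight lean towards a higher number. Compound 4 is estimated at 35 ug/mL, in the range 14 ug/mL to 90 ug/mL.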

Compound 4, half-maximal inhibitory concentration: 22 ug/mL
For compound 4 the middle estimate is 1.6-fold (0.20 log units) above the measured one; measured number inside the range.
By their numbers in this assay, from the lowest: compounds 4, 3 and 2 (each within the scatter of the next). At a limit, above all of these: compound 1.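

In this assay, going by these compounds alone, the exchange of hydroxy for amino on an aromatic carbon, para to a large group, gives a 1.1-fold lower number from compound 3 to compound 4 (0.04 log units; within the scatter) with the methoxy group kept in place, so this position tolerates either group without a readable difference between this pair, something the earlier compounds could not show because no measured step touched it. Within the data shown here, compound 4 also gives the first reading on the methoxy group itself, since putting methyl in place of the hydrogen on the oxygen of compound 2 gives a 1.7-fold lower number from compound 2 to compound 4 (0.23 log units; within the scatter), which is again no readable change and stands apart from the earlier step at that place, where methoxy replaced amino and the difference lay beyond the scatter. Nothing measured here accounts for either of these two new steps.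

Both readings rest on a single pair each and hold for these compounds alone, so they make no general rule for the shared core. Going by these compounds, what a carboxylic acid, a dimethylamino group or a longer chain such as ethoxy would do at either of these places remains open.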